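A few compounds are considered here, and "the series" means these few. Any claim that something is new, unique, unknown or untested is made for them only; others in the source may bear on it.

Notes on the series in an ADME assay (liver) for metabolic stability, with Liver microsome (Rattus norvegicus) as the target, using microsomes and NADPH, with a stated time of 30 min, at 37 degrees C, tested at 1 uM (on this read-out lower numbers stand for slow clearance and higher numbers for fast clearance), follow. Compound 2 `C[C@@](O)(c1ccc(-c2ncc(S(=O)(=O)c3ccc(N)nc3)s2)c(Cl)c1)C(F)(F)F` gives < 14 mL.min-1.g-1 as a limit of the assay, not a number. Compound 1 `Nc1ccc(S(=O)(=O)c2ccc(-c3ccc(C(O)(C(F)(F)F)C(F)(F)F)cn3)cc2)cn1` gives < 14 mL.min-1.g-1 as a limit too. Evidence so far amounts to the limit of < 14 mL.min-1.g-1 in this assay, at which 2 of the 2 values shown sit, and nothing more, and no measured step between compounds differing in one place is available. Compound 3 `Nc1ccc(S(=O)(=O)c2cnc(-c3ccc(S(N)(=O)=O)cc3Cl)s2)cn1` carries sulfamoyl in place of 1-hydroxy-1-(trifluoromethyl)ethyl on an aromatic carbon, meta to a chloro group and para to a large group, counted as sulfamoyl in place of 1-hydroxy-1-(trifluoromethyl)ethyl on an aromatic carbon for this change. In this assay no step beyond the usual scatter is expected, and no direction is favoured, so the expected step that the limit leaves unreadable from compound 2 to compound 3 stays small. For compound 3 the estimated value is 12 mL.min-1.g-1, with an expected range from 7 mL.min-1.g-1 to 25 mL.min-1.g-1 as the working figure.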

Compound 3, intrinsic clearance in microsomes: 107 mL.min-1.g-1
The estimate for compound 3 lay 8.9-fold (0.95 log units) below the measured number, outside the stated range (above it).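

In this assay, sulfamoyl in place of 1-hydroxy-1-(trifluoromethyl)ethyl on an aromatic carbon, meta to a chloro group and para to a large group, gives an at least 7.6-fold higher number from compound 2 to compound 3 (0.88 log units; beyond the scatter). For the compounds shown here, this is the first sign that the read-out depends on the group at this position, which the earlier values, both limits, could not show. Going by these compounds, the true size of the step remains unknown, as compound 2 sits at a limit of the assay and not at a number: the limit of < 14 mL.min-1.g-1 in this assay, at which 2 of the 3 values shown sit.

On these data alone, it remains open whether the step follows from the arrival of sulfamoyl or from the loss of 1-hydroxy-1-(trifluoromethyl)ethyl. As far as these compounds go, a carboxylic acid or a primary amide at the same place would help separate the two, and how either would read here is unknown.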